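The source may hold more compounds than are shown below. What is called first, only, known or untested is meant among the compounds shown, and "the series" means these compounds.

The series shares one core, carried in compound 1 `CC(C(=O)NCc1ccc(C(F)(F)F)nc1N1CCC(C)(C)CC1)c1ccc(NS(C)(=O)=O)c(F)c1`, compound 2 `C[C@H](C(=O)NCc1ccc(C(F)(F)F)nc1N1CCC(c2ccccc2)CC1)c1ccc(NS(C)(=O)=O)c(F)c1` and compound 3 `CC(C(=O)NCc1ccc(C(F)(F)F)nc1N1CCC(Cc2ccc(F)c(F)c2)CC1)c1ccc(NS(C)(=O)=O)c(F)c1`; the three differ only in the group on the saturated ring carbon of the six-membered non-aromatic ring with one nitrogen. In a functional assay on CHO-K1 cells for antagonist activity at transient receptor potential cation channel subfamily V member 1 (Homo sapiens), read by FLIPR (a lower number here means a stronger inhibitor, a higher number a weaker inhibitor), compound 1 gives 8 nM, compound 2 gives 17.4 nM, and compound 3 gives 30 nM. Compound 3 thus stands at the highest of the three numbers. Its nearest neighbour is compound 2, whose number lies within the scatter of that of compound 3, so no order between these two can be claimed. Compound 1 lies furthest from compound 3, and that gap is beyond the scatter.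

Compound 4 `CC(C(=O)NCc1ccc(C(F)(F)F)nc1N1CCC(OC(=O)C(C)(C)C)CC1)c1ccc(NS(C)(=O)=O)c(F)c1` follows from compound 3 by a single change: ((tert-butyl)carbonyl)oxy in place of 3,4-difluorobenzyl on a saturated ring carbon. Going by the values given here, no measured pair in the set shows a change of this kind, so no step between measured compounds can be drawn on. The three measured numbers sit close together although the groups at this position differ widely, and for compound 4 a step of modest size is expected a 1.2-fold lower number from compound 3 to compound 4 (0.08 log units; within the scatter), with no clear direction beyond the scatter. Compound 4 is accordingly estimated at 25 nM in this assay, with a range from 8 nM to 80 nM.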

Compound 4, half-maximal inhibitory concentration: 45.2 nM
The estimate for compound 4 lay 1.8-fold (0.26 log units) below the measured number, and the stated range covers the measured number.
By their numbers in this assay, from the lowest: compound 1; then compounds 2, 3 and 4 (each within the scatter of the next, the first and the last beyond it).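

In this assay the saturated ring carbon three ring bonds from the ring nitrogen accepts an ester group: ((tert-butyl)carbonyl)oxy in place of 3,4-difluorobenzyl gives a 1.5-fold higher number from compound 3 to compound 4 (0.18 log units; within the scatter) even though an aromatic ring leaves and hydrogen-bond acceptors enter. The dimethyl substitution of compound 1 had already shown a group with no ring at this carbon, but compound 4 is the first in the set to place hydrogen-bond acceptors there, and it stands within the scatter of compound 3 while lying beyond the scatter of compound 1. No measurement at hand accounts for this step.

The change removes the aromatic ring and brings in the ester at the same time, so the compounds shown do not separate the share of either, and a plain tert-butyl group on this carbon would be the pair needed to isolate the ester link. Also open is how this carbon responds to a free hydroxyl, a primary amine or a carboxylic acid, none of which appears among the compounds shown, since every group here carries no net charge.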